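The compounds below may be only part of what the source reports. "The series", "measured", "known", "first", "only" and "open" are said of these compounds alone.

Measured so far in a functional assay on isolated protein for inhibition of Glucose-dependent insulinotropic receptor (Rattus norvegicus), read by HTRF and cAMP accumulation; on this read-out higher numbers stand for larger maximal responses and lower numbers for smaller maximal responses:
compound 1 `Cc1nc(S(C)(=O)=O)ccc1Oc1ncnc(OC2CCN(C(=O)O[C@@H](C)C(F)(F)F)CC2)c1F` — 80%
compound 2 `Cc1nc(S(C)(=O)=O)ccc1Oc1ncnc(OC2CCN(C(=O)SC3CCC3)CC2)c1F` — 81%

In this assay compound 2 gives 81%; compound 1 gives 80%, within the scatter of it. Compound 3 `Cc1nc(S(C)(=O)=O)ccc1Oc1ncnc(OC2CCN(C(=O)C3(F)CCC3)CC2)c1F` differs from compound 2 in one place: a group of 5 heavy atoms (4 carbon, 1 fluorine; one four-membered non-aromatic ring of carbon only) in place of a group of 5 heavy atoms (4 carbon, 1 sulfur; one four-membered non-aromatic ring of carbon only), on a carbonyl carbon. Among the compounds with values here, the only step measured so far, a number 1 percentage points higher from compound 1 to compound 2 (within the scatter), also exchanged the group on that carbonyl carbon and stayed within the scatter, so it bears on this step only as a sign that the carbonyl substituent has so far hardly moved the maximal response. No step beyond the scatter is therefore expected: a number 3 percentage points lower from compound 2 to compound 3 (within the scatter). Compound 3 is estimated at 78%, in the range 62% to 92%.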

Compound 3, largest response reached (reported as efficacy), in percent of the reference or control that the assay uses: 91%
The estimate for compound 3 lay 13 percentage points below the measured number; low and high end bracket the measured number.
By their numbers in this assay, from the lowest: compounds 1, 2 and 3 (each within the scatter of the next, the first and the last beyond it).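

In this assay, the group on this carbonyl carbon now shifts the maximal response beyond the scatter: a number 11 percentage points higher from compound 1 to compound 3 (beyond the scatter) with the fluorinated four-membered ring in place of 1-(trifluoromethyl)ethoxy. Against cyclobutylsulfanyl the same group gives a number 10 percentage points higher from compound 2 to compound 3 (within the scatter), so only the wider of the two gaps separates the compounds. No measurement shown here accounts for either step.

Open, from the compounds shown here alone, is how the response changes with a plain cyclobutyl group or a cyclobutylamino group on this carbonyl carbon. Whether the fluorine contributes to the step therefore remains unresolved.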